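The source may hold more compounds than are shown below. What is called first, only, known or untested is meant among the compounds shown, and "the series" means these compounds.

Four stilbene-like compounds are compared in a functional assay on MOLT-4 cells (Homo sapiens), read by cell counting, with a stated time of 72 h; on this read-out lower numbers stand for stronger inhibition and higher numbers for weaker inhibition. Compound 1 `COc1ccc(/C=C/c2ccc(F)cc2)cc1` and compound 2 `COc1ccc(/C=C/c2ccc(C)cc2)cc1` share one core, while compound 3 `Cc1ccc(/C=C/c2ccccc2F)cc1` and compound 4 `Fc1ccc(/C=C/c2ccccc2F)cc1` share another; the difference between the two cores is not broken down here.

In this assay compound 1 gives only a limit, > 200 ug/mL. Compound 2 likewise gives only a limit, > 200 ug/mL. Compound 3, however, gives a number, 30 ug/mL, the only one among the three measured values.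

The change from compound 2 to compound 1 is fluoro in place of methyl on an aromatic carbon, and its step, a step that the two limits leave unreadable from compound 2 to compound 1, cannot be read because both values sit at the limit of > 200 ug/mL in this assay, at which 2 of the 3 values shown sit.

The change from compound 3 to compound 4 is fluoro in place of methyl on an aromatic carbon, the same kind of change, though here the place is para to a group of 9 heavy atoms rather than para to a large group. Since the earlier step gives no readable size, the expectation for compound 4 rests on compound 3 alone, whose value is 30 ug/mL. Compound 4 is therefore expected to show a step of a 1.3-fold higher number from compound 3 to compound 4 (0.12 log units; within the scatter), and its estimated value in this assay is 40 ug/mL, between 15 ug/mL and 120 ug/mL.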

Compound 4, half-maximal inhibitory concentration: 61 ug/mL
Beside the measured number, compound 4's estimate is 1.5-fold (0.18 log units) below it; measured number inside the range.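

In this assay, putting fluoro in place of methyl on an aromatic carbon of the core of compound 3 gives a 2.0-fold higher number from compound 3 to compound 4 (0.31 log units; beyond the scatter), so on this core the change brings weaker inhibition. The same change on the core of compound 2 cannot be read, because compound 2 and compound 1 both give a limit rather than a number: the limit of > 200 ug/mL in this assay, at which 2 of the 4 values shown sit. That leaves a single readable example of this change, which shows what it does on one core but not whether its direction or size carries over to another core.

On the core of compound 3, the compounds shown hold only methyl and fluoro at this place, para to a group of 9 heavy atoms, so it stays open how an amine, a carboxylic acid or a nitrile would read there. Going by these compounds, a longer chain, such as ethyl or propyl, is equally open, and so is whether any of these groups would restore or further weaken inhibition.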